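The source may hold more compounds than are shown below. What is called first, only, known or untested is meant among the compounds shown, and "the series" means these compounds.

Of the compounds shown here, three sharing one core have been measured in a physicochemical assay for solubility, read by HPLC, with a stated time of 24 h; a higher number here means a more soluble compound, a lower number a less soluble compound. Compound 1 `O=C1CCC(=O)N1C[C@H]1CN(c2ccc(-n3cc(-c4ccccn4)cn3)c(F)c2)C(=O)O1` gives 45300 nM. Compound 2 `O=C1CNC(=O)N1C[C@H]1CN(c2ccc(-n3cc(-c4ccccn4)cn3)c(F)c2)C(=O)O1` gives 1630000 nM, which is a 36-fold higher number from compound 1 to compound 2 (1.56 log units; beyond the scatter). Compound 3 `O=C1O[C@@H](Cn2ccnn2)CN1c1ccc(-n2cc(-c3ccccn3)cn2)c(F)c1` gives 247000 nM, standing second highest of the three numbers; its nearest neighbour is compound 1, and the gap is a 5.5-fold higher number from compound 1 to compound 3 (0.74 log units; beyond the scatter), while against compound 2 the gap is a 6.6-fold lower number from compound 2 to compound 3 (0.82 log units; beyond the scatter).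

Compound 4 `O=C1O[C@@H](CNC(=O)C(F)(F)F)CN1c1ccc(-n2cc(-c3ccccn3)cn2)c(F)c1` is the next in this series, and the change from compound 3 is ((trifluoromethyl)carbonyl)amino in place of 1H-1,2,3-triazol-1-yl on a saturated chain carbon bound to a saturated ring carbon. Within the data shown here, none of the three measured steps repeats this exact change; each of them replaces the group on the saturated chain carbon bound to a saturated ring carbon with a different one, so they show only that exchanging the group at this place moves the solubility by modest to large amounts, in either direction. The step into compound 4 is therefore expected to be of modest size, most likely upward, giving an estimated 1.4-fold higher number from compound 3 to compound 4 (0.15 log units; within the scatter). For compound 4 the expected solubility in this assay is 350000 nM, with a range from 120000 nM to 1000000 nM.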

Compound 4, solubility: 114000 nM
Beside the measured number, compound 4's estimate is 3.1-fold (0.49 log units) above it; measured number outside the range, below it.
By their numbers in this assay, from the lowest: compound 1; then compound 4; then compound 3; then compound 2.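

In this assay, the ((trifluoromethyl)carbonyl)amino group is the first group shown with no ring on this saturated chain carbon bound to a saturated ring carbon, and it ranks under the 1H-1,2,3-triazol-1-yl group (a 2.2-fold lower number from compound 3 to compound 4 (0.34 log units; beyond the scatter)). It also ranks far under the 2,5-dioxoimidazolidin-1-yl group (a 14-fold lower number from compound 2 to compound 4 (1.16 log units; beyond the scatter)) but over the 2,5-dioxopyrrolidin-1-yl group (a 2.5-fold higher number from compound 1 to compound 4 (0.40 log units; beyond the scatter)), so the group without a ring falls inside the span set by the three ring groups and the presence of a ring at this place does not by itself decide the order, with compound 1 going against any rule that ring groups rank higher. Nothing measured here accounts for this order.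

The compounds shown leave open how much of this result belongs to the trifluoromethyl and how much to the amide link, which a plain acetylamino group at the same place would help to separate. They also leave open where a primary amine or a carboxylic acid on this saturated chain carbon would rank in the same order.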